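Methylating an Amine Nitrogen in Two Related Cores

The source may hold more compounds than are shown below. What is called first, only, known or untested is meant among the compounds shown, and "the series" means these compounds.

Of the compounds shown here, three have been measured in a functional assay on MCF7 cells (Homo sapiens) for antiproliferative activity, read by MTT assay, with a stated time of 48 h; on this read-out lower numbers stand for stronger inhibition and higher numbers for weaker inhibition. Compound 1 `COc1ccc(C(=O)c2ccc(OC)c3c2OC(C)(C)C=C3)c(NC(=O)CN)c1` gives 410 nM in this assay. Compound 2 `CNCC(=O)Nc1cc(OC)ccc1C(=O)c1ccc(OC)c2c1OC(C)(C)C=C2` differs from compound 1 by one change: methyl in place of hydrogen on an amine nitrogen. In this assay compound 2 gives 820 nM. On this assay the step is a 2.0-fold higher number from compound 1 to compound 2 (0.30 log units; within the scatter). Compound 3 `C=C(c1ccc(OC)cc1NC(=O)CN)c1ccc(OC)c2c1C=CC(C)(C)O2` has a different core; the difference between the two cores is not broken down here. In this assay compound 3 gives 780 nM, a value that lies within the scatter of the value of compound 2, so no order between compound 2 and compound 3 can be read from these numbers.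

Compound 4 `C=C(c1ccc(OC)cc1NC(=O)CNC)c1ccc(OC)c2c1C=CC(C)(C)O2` has not yet been measured. It differs from compound 3 by methyl in place of hydrogen on an amine nitrogen, which is the same change that separates compound 1 from compound 2, made at a place described in the same words. Among the compounds with values here, with only one earlier example, the expectation for compound 4 rests on that single pair: because the step of a 2.0-fold higher number from compound 1 to compound 2 (0.30 log units; within the scatter) was small, a step of similar size is expected here. The estimated step in this assay is a 1.8-fold higher number from compound 3 to compound 4 (0.25 log units; within the scatter). Compound 4 is therefore expected to give about 1400 nM in this assay, with a plausible range from 600 nM to 3500 nM, before the measurement is known.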

Compound 4, half-maximal inhibitory concentration: 1010 nM
Beside the measured number, compound 4's estimate is 1.4-fold (0.14 log units) above it; the measured number falls inside the stated range.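

In this assay, the same swap of methyl for hydrogen on an amine nitrogen, now made on the second core, gives a 1.3-fold higher number from compound 3 to compound 4 (0.11 log units; within the scatter). Set beside the step on the first core, it shows that this change can be carried from one core to the other without any measurable difference in its size, and the two steps agree as closely as repeated measurements of this kind allow: the same change on two cores in this assay, a 2.0-fold higher number (0.30 log units; within the scatter) from compound 1 to compound 2 and a 1.3-fold higher number (0.11 log units; within the scatter) from compound 3 to compound 4, 1.5-fold (0.19 log units) apart, within the scatter of two such steps This does not show that methylation weakens the antiproliferative effect, since each step on its own lies within the scatter, and two pairs cannot establish a rule for the whole series or show that the step has one fixed size.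

The compounds shown leave open whether a group larger than methyl on this nitrogen, such as ethyl or a second methyl, would produce a step that clearly exceeds the scatter. They also leave open what would follow if the aminomethyl part gave way to a longer chain or a carboxylic acid, and whether the small step would hold on a third core.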